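Des-fluoro analogue of compound 3: expected oral exposure

The source may hold more compounds than are shown below. What is called first, only, known or untested is meant among the compounds shown, and "the series" means these compounds.

Within the data shown here, compound 3 `Cc1nc(C)n(CC(=O)N2CCN(c3sc(C(F)(F)F)nc3-c3nc4c(F)cccc4[nH]3)C[C@H]2C)n1` stands highest of the three compounds measured so far in an ADME assay on the whole organism (Mus musculus, strain Balb/c) for pharmacokinetics, at a dose of 10 mg/kg by the oral route (on this read-out higher numbers stand for higher exposure at the dose given and lower numbers for lower exposure), giving 13400 nM. Compound 2 `Cc1nn(CC(=O)N2CCN(c3sc(C(F)(F)F)nc3-c3nc4ccccc4[nH]3)C[C@H]2C)cc1CN(C)C` gives 472 nM and compound 1 `Cc1nc(C)n(CC(=O)N2CCN(c3sc(C(F)(F)F)nc3-c3nc4ccc(C5CCN(C)CC5)cc4[nH]3)C[C@H]2C)n1` gives 50.7 nM in this assay; each differs from compound 3 in more than one place, so their values show only the spread across the series. Compound 4 `Cc1nc(C)n(CC(=O)N2CCN(c3sc(C(F)(F)F)nc3-c3nc4ccccc4[nH]3)C[C@H]2C)n1` is the next step from compound 3: hydrogen in place of fluoro on an aromatic carbon. Among the measured compounds shown here, no step between two measured compounds that differ in a single place is available for this assay. Loss of the fluoro is expected to lower exposure in this assay, by a step beyond the scatter, with the size uncertain. Compound 4 is estimated at 3000 nM, within 600 nM to 15000 nM. The expected step is a 4.5-fold lower number from compound 3 to compound 4 (0.65 log units; beyond the scatter).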

Compound 4, maximal plasma concentration in the Mus musculus assay: 10100 nM
Estimate against measurement, compound 4: 3.4-fold (0.53 log units) below; the measured number falls inside the stated range.
By their numbers in the Mus musculus assay, from the lowest: compound 1; then compound 2; then compounds 4 and 3 (each within the scatter of the next).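

In the Mus musculus assay the change from 4-fluoro-1H-benzimidazol-2-yl to 1H-benzimidazol-2-yl gives a 1.3-fold lower number from compound 3 to compound 4 (0.12 log units; within the scatter), so this position tolerates loss of the fluoro, whereas a 21-fold higher number from compound 2 to compound 4 (1.33 log units; beyond the scatter) and a 200-fold higher number from compound 1 to compound 4 (2.30 log units; beyond the scatter) show that changes at the other two places matter far more. In a physicochemical assay for lipophilicity, at pH 7.4 (on this read-out lower numbers stand for lower lipophilicity and higher numbers for higher lipophilicity), compound 3 gives 3.6 and compound 4 gives 3.3, a pair within the scatter. Nothing available accounts for any of these steps.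

On these data alone, whether a chloro, methoxy or carboxylic acid on this aromatic carbon would also leave exposure in the range of compound 4 remains open.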